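Aryl variation on the triazinedione ring nitrogen: compound 4

The source may report more compounds than this note shows. Statements on the series, on what has been measured and on what is new or still open speak of the compounds shown alone.

Measured so far:
- compound 2 `Cn1c(=O)c(C(=O)Nc2ccc(Oc3ccncc3-c3cccnc3)c(F)c2)nn(-c2ccccc2F)c1=O`: 6760 nM
- compound 3 `Cn1c(=O)c(C(=O)Nc2ccc(Oc3ccncc3-c3cccnc3)c(F)c2)nn(-c2ccc(Cl)cc2)c1=O`: 3220 nM
- compound 1 `COc1ccc(Nc2cc(Nc3ccc(Oc4ccncc4-c4cccnc4)c(F)c3)ncn2)cc1`: "not determined" (no result reported)

In a functional assay on MDA-MB-231 cells (Homo sapiens) for cytotoxicity, read by MTT assay, with a stated time of 72 h (a lower number here means a stronger inhibitor, a higher number a weaker inhibitor), compound 2 gives 6760 nM, and compound 3 gives 3220 nM. Compound 1 has "not determined" (no result reported) in this assay. Going by the values given here, compound 3 thus holds the lowest of the two numbers available, and its only measured neighbour is compound 2, separated by a 2.1-fold lower number from compound 2 to compound 3 (0.32 log units; beyond the scatter), a modest step that lies beyond the scatter.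

Compound 4 `Cn1c(=O)c(C(=O)Nc2ccc(Oc3ccncc3-c3cccnc3)c(F)c2)nn(-c2cccc(C(F)(F)F)c2)c1=O` differs from compound 3 by 3-(trifluoromethyl)phenyl in place of 4-chlorophenyl on an aromatic nitrogen. Among the compounds with values here, the one step that bears on this position is the exchange from compound 2 to compound 3, which moved the number by a 2.1-fold lower number from compound 2 to compound 3 (0.32 log units; beyond the scatter). That step swapped one substituted phenyl for another at the same nitrogen and produced only a modest shift, so a further swap of the aryl group is expected to leave the number near that of compound 3, with a change of at most similar size in either direction and quite possibly none beyond the scatter.

Compound 4 is therefore estimated at 3500 nM, within 1400 nM to 9000 nM. The step that this estimate means is expected to be a 1.1-fold higher number from compound 3 to compound 4 (0.04 log units; within the scatter), inside the scatter.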

Compound 4, half-maximal inhibitory concentration: 3980 nM
Compound 4: middle estimate off by 1.1-fold (0.06 log units), on the low side; the measured number falls inside the stated range.
By their numbers in this assay, from the lowest: compounds 3, 4 and 2 (each within the scatter of the next, the first and the last beyond it).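

In this assay, the exchange of 4-chlorophenyl for 3-(trifluoromethyl)phenyl on the aromatic nitrogen gives a 1.2-fold higher number from compound 3 to compound 4 (0.09 log units; within the scatter), so a group with more heavy atoms and fluorine in place of chlorine leaves a number that cannot be told apart from that of compound 3. Replacing 2-fluorophenyl with the same group gives a 1.7-fold lower number from compound 2 to compound 4 (0.23 log units; within the scatter), so compound 4 also cannot be told apart from compound 2, although a 2.1-fold lower number from compound 2 to compound 3 (0.32 log units; beyond the scatter) lies beyond the scatter; compound 4 therefore cannot be ranked against either neighbour, and the three aryl groups give no clear order that includes it. No data are available here that would explain how closely these numbers lie together.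

From the compounds shown here alone, it remains open whether this tolerance extends beyond halogen-bearing and trifluoromethyl-bearing phenyl groups, for example to a phenyl ring carrying an amine or a carboxylic acid, or to a longer alkyl chain in place of the aryl ring on the same nitrogen. The effect of the substituent also cannot be separated from that of its ring position, since no compound shown carries the same substituent at two different ring positions.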